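Notes on the aryl change from compound 2 to compound 4

A few compounds are considered here, and "the series" means these few. Any claim that something is new, unique, unknown or untested is made for them only; others in the source may bear on it.

Compound 2 `CCCN(CC[C@H]1CC[C@H](NC(=O)/C=C/c2cccc(Cl)c2)CC1)[C@H]1CCc2nc(N)sc2C1` gives 1.2 nM in an assay on brain for displacement of a labelled ligand from D(3) dopamine receptor (Rattus norvegicus); a lower number here means a stronger inhibitor, a higher number a weaker inhibitor. Compound 3 `CCCN(CC[C@H]1CC[C@H](NC(=O)/C=C/c2ccccc2Cl)CC1)[C@H]1CCc2nc(N)sc2C1` gives 1.2 nM, and with no change at the digits printed from compound 2 to compound 3 (within the scatter) the two stand level and together hold the lowest numbers of the three. Compound 1 `CCCN(CC[C@H]1CC[C@H](NC(=O)/C=C/c2ccc(Cl)cc2)CC1)[C@H]1CCc2nc(N)sc2C1` gives 2.5 nM; the steps of a 2.1-fold lower number from compound 1 to compound 2 (0.32 log units; beyond the scatter) and a 2.1-fold lower number from compound 1 to compound 3 (0.32 log units; beyond the scatter) set compound 1 apart from the other two by a modest margin, and nothing in this assay separates compound 2 from compound 3.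

Compound 4 `CCCN(CC[C@H]1CC[C@H](NC(=O)/C=C/c2ccccc2OC)CC1)[C@H]1CCc2nc(N)sc2C1` carries the change (2-methoxyphenyl in place of 3-chlorophenyl on a double-bonded chain carbon bound to a double-bonded chain carbon). Two parts are folded into this change: the substituted ring changes from 3-chlorophenyl to a ring substituted at the 2-position, and the substituent itself changes from chlorine to methoxy. The first part is addressed by no change at the digits printed from compound 2 to compound 3 (within the scatter), which shows no movement between the 3-chlorophenyl and 2-chlorophenyl rings. Among the measured compounds shown here, the second part, chlorine to methoxy on this ring, has no measured counterpart among the three compounds, so the expectation carries extra uncertainty on that side. A step of a 1.7-fold higher number from compound 2 to compound 4 (0.22 log units; within the scatter) is expected, near the edge of the scatter and with no firm direction. Compound 4 is estimated at 2 nM, with a range from 0.6 nM to 7 nM.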

Compound 4, inhibition constant: 8.1 nM
Compound 4: the middle estimate sits 4.1-fold (0.61 log units) below what was measured; the measured number lies above the stated range.
By their numbers in this assay, from the lowest: compounds 2 and 3 (each within the scatter of the next); then compound 1; then compound 4.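

In this assay, the pair that isolates the substituent is read through a 6.8-fold higher number from compound 3 to compound 4 (0.83 log units; beyond the scatter): only methoxy in place of chloro on an aromatic carbon separates the two, and this is the part of the change that the chloro compounds alone could not address. The full change from 3-chlorophenyl to 2-methoxyphenyl is of the same size, a 6.8-fold higher number from compound 2 to compound 4 (0.83 log units; beyond the scatter), and as compound 2 and compound 3 print level, the whole step in this set tracks the exchange of chloro for methoxy, not the place of the chlorine. Among the compounds shown here, the step of a 3.2-fold higher number from compound 1 to compound 4 (0.51 log units; beyond the scatter) is also beyond the scatter, so among the four compounds, each of the three chlorophenyl compounds gives a lower number than the 2-methoxyphenyl compound, with no compound going against this.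

Nothing shown gives a reason for the higher number that comes with methoxy. Still open, as far as these compounds go, are whether a hydroxy or a methyl group in place of the methoxy of 2-methoxyphenyl would give a number nearer the chloro compounds, and whether methoxy at the places held by chlorine in 3-chlorophenyl and 4-chlorophenyl would carry a step of similar size.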